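This account rests on a few compounds, and the source may have more. Where it says the series, first, only, none or still open, it means among the compounds named here.

Series notes. Compound 1 `Nc1ccccc1NC(=O)c1ccc(CSC(=S)N2CCN(c3ccc(Cl)cc3)CC2)cc1`, compound 2 `N#Cc1ccc(N2CCN(C(=S)SCc3ccc(C(=O)Nc4ccccc4N)cc3)CC2)cc1` and compound 3 `Cc1ccc(N2CCN(C(=S)SCc3ccc(C(=O)Nc4ccccc4N)cc3)CC2)cc1` share one core and differ only in one substituent on an aromatic carbon. In a functional assay on A-375 cells (Homo sapiens) for antiproliferative activity, read by CCK-8 assay, with a stated time of 72 h, tested at 2 uM (on this read-out higher numbers stand for a stronger effect at the one concentration tested and lower numbers for a weaker effect), compound 1 gives 32.2%, compound 2 gives 41.4% and compound 3 gives 25.8%. Compound 3 stands lowest of the three numbers, though its gap to compound 1 lies within the scatter: a number 6.4 percentage points lower from compound 1 to compound 3 (within the scatter). The other steps are a number 9.2 percentage points higher from compound 1 to compound 2 (within the scatter) and a number 15.6 percentage points lower from compound 2 to compound 3 (beyond the scatter).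

Compound 4 `Nc1ccccc1NC(=O)c1ccc(CSC(=S)N2CCN(Cc3cccnc3)CC2)cc1` is not yet measured. Its change from compound 3 is (pyridin-3-yl)methyl in place of 4-methylphenyl on an amine nitrogen in a ring. None of the three measured steps bears on it directly: each replaces a single substituent on an aromatic carbon, whereas here the 4-methylphenyl leaves entirely and a (pyridin-3-yl)methyl, with its six-membered aromatic ring with 1 hetero atom, enters on the amine nitrogen in a ring. The measured steps span only a modest range, so no step beyond the scatter is expected from compound 3, and the estimated step is a number 4.2 percentage points higher from compound 3 to compound 4 (within the scatter). Compound 4 is expected to give about 30% in this assay, within 10% to 50%.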

Compound 4, a percentage reported as inhibition, at one concentration (the size of the read-out at that concentration, not a potency): 31.5%
Compound 4: the middle estimate sits 1.5 percentage points below what was measured, and the stated range covers the measured number.
By their numbers in this assay, from the lowest: compounds 3, 4, 1 and 2 (each within the scatter of the next, the first and the last beyond it).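

The amine nitrogen in the ring accepts a change of the whole group, not only of a substituent on an aromatic carbon: with (pyridin-3-yl)methyl in place of the aryl groups, this assay gives three steps within the scatter (a number 5.7 percentage points higher from compound 3 to compound 4 (within the scatter); a number 0.7 percentage points lower from compound 1 to compound 4 (within the scatter); a number 9.9 percentage points lower from compound 2 to compound 4 (within the scatter)). Compound 4 therefore falls within the scatter of all three earlier compounds, including compound 2 and compound 3, the pair whose own step lies beyond it. Nothing measured here explains why the read-out stays within this band.

The compounds shown leave open whether the one-carbon link or the ring nitrogen of the pyridine counts for more, which a benzyl group on the same nitrogen would begin to separate. On these data alone, it also remains open how a group with no aromatic ring at all, such as a simple ethyl or a longer chain ending in an amine, would read at this position.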